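Opening the Hydroxybutyl Chain into a Hydroxypyrrolidine Ring

The source may hold more compounds than are shown below. What is called first, only, known or untested is meant among the compounds shown, and "the series" means these compounds.

Among the measured compounds shown here, in an ADME assay on MT4 cells (Homo sapiens) for cytotoxicity, read by MTT assay, with a stated time of 5 days (a higher number here means that more compound is tolerated, a lower number that less compound is tolerated), compound 2 (`COc1cc2cc(C#N)ccc2c(OC)c1Oc1cc(NCCCCO)nc(Nc2ccc(C#N)cc2)n1`) gives 39100 nM as the only actual number so far. Compound 1 (`COc1cc2cc(C#N)ccc2c(OC)c1Oc1cc(NC2CCOCC2)nc(Nc2ccc(C#N)cc2)n1`) is reported only as a limit, > 125000 nM and no number. Compound 3 (`COc1cc2cc(C#N)ccc2c(OC)c1Oc1cc(N2CCC(O)C2)nc(Nc2ccc(C#N)cc2)n1`) keeps the shared core but carries 3-hydroxypyrrolidin-1-yl in place of (4-hydroxybutyl)amino on an aromatic carbon, next to the ring nitrogen (3-hydroxypyrrolidin-1-yl in place of (4-hydroxybutyl)amino on an aromatic carbon). For the measured compounds named here, one measured step bears on this change: 4-hydroxybutyl in place of oxan-4-yl gave an at least 3.1-fold lower number from compound 1 to compound 2 (0.50 log units; beyond the scatter) and so lay beyond the scatter. Compound 3 restores a ring where compound 2 has the open chain, so that step, read backwards, points towards more compound being tolerated. The expected change is smaller, a 1.7-fold higher number from compound 2 to compound 3 (0.22 log units; within the scatter) in this assay as a rough estimate. Compound 3 is estimated at 65000 nM with an expected range of 25000 nM to 125000 nM in all.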

Compound 3, half-maximal cytotoxic concentration: > 125000 nM
Compound 3: only a limit was reported (the forecaster's own chance of this, stated with the estimate: 25%); at least 1.9-fold (0.28 log units) between middle value and limit.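

In this assay, 3-hydroxypyrrolidin-1-yl in place of (4-hydroxybutyl)amino, on the aromatic carbon next to the ring nitrogen, gave an at least 3.1-fold higher number from compound 2 to compound 3 (0.50 log units; beyond the scatter). Before this result, only the (oxan-4-yl)amino group had been seen at the limit of the assay; now a second ring-bearing group, of the same heavy-atom count as the open chain, is there too, while the open-chain compound 2 alone gives an actual number. Compound 3 also keeps a hydroxy group, so a hydroxy group at this position does not by itself go with the lower number. The step between compound 1 and compound 3 cannot be read: the limit of > 125000 nM in this assay, at which 2 of the 3 values shown sit.

From the compounds shown here alone, how far compound 1 and compound 3 lie beyond the limit stays open. So does whether a pyrrolidine without the hydroxy group, or a butylamino chain without it, would reach the limit or give a number.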